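A few compounds are considered here, and "the series" means these few. Any claim that something is new, unique, unknown or untested is made for them only; others in the source may bear on it.

Measured so far in this series:
compound 1 `O=C(Nc1ccc2nc(NC(=O)C3CCCCC3)sc2c1)c1ccccc1F`: 0.14 ug/mL
compound 2 `CC(C)COC(=O)Nc1ccc2nc(NC(=O)C3CCCCC3)sc2c1`: 0.72 ug/mL
compound 3 `O=C(O)CCC(=O)Nc1nc2ccc(NC(=O)c3c(Cl)cccc3Cl)cc2s1`: > 6.6 ug/mL

In a functional assay on WI-38 VA13 cells (Homo sapiens) for cytotoxicity (on this read-out lower numbers stand for an effect already at smaller amounts and higher numbers for an effect only at larger amounts of compound), compound 1 gives 0.14 ug/mL. Compound 2 gives 0.72 ug/mL in this assay; isobutoxy in place of 2-fluorophenyl on a carbonyl carbon gives a 5.1-fold higher number from compound 1 to compound 2 (0.71 log units; beyond the scatter). For compound 3 only a limit of the assay is known, > 6.6 ug/mL in this assay. Compound 3 therefore stands at the limit of > 6.6 ug/mL in this assay, at which 1 of the 3 values shown sits, and has no number that can be set against the other two.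

Compound 4 `CCCCCCNC(=O)Nc1nc2ccc(NC(=O)c3c(Cl)cccc3Cl)cc2s1` is not yet measured. It differs from compound 3 by hexylamino in place of 2-carboxyethyl on a carbonyl carbon. Going by the values given here, no measured step touches the same part of the molecule: the change from compound 1 to compound 2 concerns a different acyl group, and its size, a 5.1-fold higher number from compound 1 to compound 2 (0.71 log units; beyond the scatter), shows only that such swaps move the read-out modestly. Among the compounds with values here, because compound 3 sits at the limit of > 6.6 ug/mL in this assay, at which 1 of the 3 values shown sits, the starting point for the step is itself open, and the hexylamino group has no counterpart among the measured compounds.

Compound 4 is therefore expected somewhere near 3 ug/mL, with a wide range from 0.8 ug/mL to 10 ug/mL, and a fair chance that it too is reported only as a limit. The step expected is an at least 2.2-fold lower number from compound 3 to compound 4 (0.34 log units; beyond the scatter).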

Compound 4, half-maximal effective concentration: 0.29 ug/mL
Estimate against measurement, compound 4: 10-fold (1.01 log units) above, outside the stated range (below it).
By their numbers in this assay, from the lowest: compound 1; then compound 4; then compound 2. At a limit, above all of these: compound 3.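

Going by these compounds alone, on a carbonyl carbon whose other neighbour is an amide-type nitrogen, hexylamino in place of 2-carboxyethyl gives an at least 22-fold lower number from compound 3 to compound 4 (1.35 log units; beyond the scatter) in this assay, the first measured change at this place and a large one. The earlier step, a 5.1-fold higher number from compound 1 to compound 2 (0.71 log units; beyond the scatter), concerned a different acyl group and was modest, so the read-out can respond more strongly to a change at this place than that step alone indicated. The new step has only a lower bound on its size, since its starting point is a limit and not a number: the limit of > 6.6 ug/mL in this assay, at which 1 of the 4 values shown sits.

The compounds shown cannot separate the loss of the 2-carboxyethyl group from the entry of hexylamino, since both changes occur in a single step; a methyl ester of the carboxylic acid or a butylamino chain on the same carbonyl carbon would begin to tell these two contributions apart. As far as these compounds go, it also remains open whether hexylamino gives a step of similar size when the 2-fluorophenyl or isobutoxy acyl partner of compound 1 or compound 2 replaces the acyl group shared by compound 3 and compound 4.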